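Isopropyl for dimethylamino on the benzamide arm of compound 2

The source may hold more compounds than are shown below. What is called first, only, known or untested is meant among the compounds shown, and "the series" means these compounds.

Measured compounds:
compound 1, `CC(C)c1ccc(C(=O)N(Cc2ccc(C(=O)NO)cc2)C(C)(C)C(=O)NC2CCCCC2)cc1`, 270 nM
compound 2, `CN(C)c1ccc(C(=O)N(Cc2ccc(C(=O)NO)cc2)C(C)(C)C(=O)NCc2ccccc2)cc1`, 70 nM

Two compounds have numbers in an assay on Sf9 cells for inhibition of protein deacetylase HDAC6 (Homo sapiens), read by fluorescence, with a stated time of 90 min; a higher number here means a weaker inhibitor, a lower number a stronger inhibitor. Compound 2 gives 70 nM, the lower of the two, and compound 1 gives 270 nM, a gap beyond the scatter; compound 1 differs from compound 2 in more than one place, so its value cannot be tied to a single change. Compound 3, `CC(C)c1ccc(C(=O)N(Cc2ccc(C(=O)NO)cc2)C(C)(C)C(=O)NCc2ccccc2)cc1`, is not yet measured. It differs from compound 2 in one place: isopropyl in place of dimethylamino on an aromatic carbon. Compound 1 also carries isopropyl at that position and gives the higher number, but its other differences leave the contribution of this change unknown. A modest weakening from compound 2 to compound 3 is expected, estimated at a 2.1-fold higher number from compound 2 to compound 3 (0.33 log units; beyond the scatter) in this assay, though a result within the scatter would not surprise. Compound 3 is therefore expected to give about 150 nM, between 50 nM and 450 nM.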

Compound 3, half-maximal inhibitory concentration: 60 nM
Compound 3: the middle estimate sits 2.5-fold (0.40 log units) above what was measured; measured number inside the range.
By their numbers in this assay, from the lowest: compounds 3 and 2 (each within the scatter of the next); then compound 1.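

In this assay the change from dimethylamino to isopropyl on the aromatic carbon para to a large group gives a 1.2-fold lower number from compound 2 to compound 3 (0.07 log units; within the scatter) and so shows that this position takes either group, whether or not it carries a nitrogen. Benzyl in place of cyclohexyl on an amide-type nitrogen gives a 4.5-fold lower number from compound 1 to compound 3 (0.65 log units; beyond the scatter) and thereby ties the higher number of compound 1 to that nitrogen substituent and not to the isopropyl group, which compound 3 shares. No measurement shown here explains either step.

The compounds shown leave open whether a carboxylic acid or a longer alkyl chain on that aromatic carbon would read the same as these two groups. They also leave open how a phenethyl group or a cyclohexylmethyl group on the amide-type nitrogen would compare with benzyl and cyclohexyl.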